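The source may report more compounds than this note shows. Statements on the series, on what has been measured and on what is new or still open speak of the compounds shown alone.

Compound 1 `C=CCCC(=O)N[C@H]1[C@@H](OCCc2ccccc2)O[C@H](CO)[C@@H](O)[C@@H]1O` – in a functional assay on C6 cells (Rattus norvegicus), read by thymidine incorporation (a higher number here means a weaker inhibitor, a lower number a stronger inhibitor), compound 1 gives only the limit of the measurement, > 50 uM.
Compound 2 `CCCCC(=O)N[C@H]1[C@@H](OCCc2ccccc2)O[C@H](COCC(CO)(CO)CO)[C@@H](O)[C@@H]1O` – in this assay compound 2 gives only the limit of the measurement, > 50 uM.
Compound 3 `CCCCCCCCCCCCCCCCO[C@H]1O[C@H](COC[C@@H](O)CO)[C@@H](O)[C@H](O)[C@H]1NC(=O)CCCC` – in this assay compound 3 has "not determined" (no result reported), so no result is reported for it.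

In this assay compound 1 reaches only the limit of the measurement, > 50 uM, and not a number. Compound 2 likewise stops at the limit, > 50 uM. Compound 3 has no result in this assay at all, its entry reading "not determined" (no result reported). So compound 1 stands nowhere in particular: there is no number for it, only (the limit of > 50 uM in this assay, at which 2 of the 3 values shown sit), and no other measured pair allows a step to be sized.

Compound 4 `C=CCCC(=O)N[C@H]1[C@@H](OCCc2ccccc2)O[C@H](CO)[C@@H](O)[C@@H]1OS(=O)(=O)O` is the next compound to be tested. It differs from compound 1 by sulfo in place of hydrogen on an oxygen on a saturated carbon, or, read one bond further out, hydroxy to sulfooxy. Within the data shown here, no measured step in this set involves such a change, so nothing in the data points to a direction for it. Since compound 1 is itself only a limit, a step from compound 1 to compound 4 cannot be properly sized either way; the estimate is that it stays near the limit.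

For compound 4 the expected value in this assay is 50 uM, with a range from 10 uM to 200 uM. This expectation corresponds to a step of a number no higher from compound 1 to compound 4 (the limit leaves the size open), and it is most likely that compound 4 will again be reported only as a limit.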

Compound 4, concentration for 50% inhibition: > 50 uM
Compound 4 ended at the assay's limit; the forecaster's own chance of this, stated with the estimate: 70%; the middle value lies on the limit itself.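

In this assay compound 4 gives > 50 uM, which is a limit and not a number. Among these compounds, compound 1 also stands only at a limit, so no step from compound 1 to compound 4 can be read. The compounds shown leave open how strongly any of them inhibits, and whether hydroxy to sulfooxy changes the result at all: the limit of > 50 uM in this assay, at which 3 of the 4 values shown sit.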